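The source may hold more compounds than are shown below. What is called first, only, known or untested is meant among the compounds shown, and "the series" means these compounds.

Compound 2 `CCN(c1ccc(C#N)c(Cl)c1)c1cc(-c2cccnc2)ccc1C`: 2000 nM
Compound 1 `CCN(c1ccc(C#N)c(Cl)c1)c1cc(-c2ccoc2)ccc1C`: a limit, > 30000 nM

In a functional assay on CWR22R cells (Homo sapiens) for antiproliferative activity, read by CCK-8 assay, with a stated time of 6 days (a lower number here means a stronger inhibitor, a higher number a weaker inhibitor), compound 2 gives 2000 nM, the only number shown in this series. Compound 1 gives no number but only a limit, > 30000 nM, namely (the limit of > 30000 nM in this assay, at which 1 of the 2 values shown sits). Compound 3 `CCN(c1ccc(C#N)c(Cl)c1)c1cc(-n2cccn2)ccc1C` is the compound still to be measured; it differs from compound 2 by 1H-pyrazol-1-yl in place of pyridin-3-yl on an aromatic carbon. Within the data shown here, the one measured step that bears on this change is an at least 15-fold lower number from compound 1 to compound 2 (1.17 log units; beyond the scatter), where furan-3-yl gave way to pyridin-3-yl. The group entering in compound 3, 1H-pyrazol-1-yl, is again one five-membered aromatic ring, as furan-3-yl was, yet it carries 2 hetero atoms and 2 hydrogen-bond acceptors, so the change runs partly back toward compound 1 and partly keeps what distinguished compound 2. The writer therefore expects compound 3 to fall between the two, with a 3.0-fold higher number from compound 2 to compound 3 (0.48 log units; beyond the scatter) as a step beyond the scatter toward weaker inhibition but short of the limit. The estimate for compound 3 is 6000 nM, with a range from 1500 nM to 30000 nM.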

Compound 3, half-maximal inhibitory concentration: > 30000 nM
Compound 3 ended at the assay's limit; the forecaster's own chance of this, stated with the estimate: 25%; middle value at least 5.0-fold (0.69 log units) from the limit.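

The change at this position, on an aromatic carbon para to a methyl group, can now be read from the side of the active compound: 1H-pyrazol-1-yl in place of pyridin-3-yl brings an at least 15-fold higher number from compound 2 to compound 3 (1.17 log units; beyond the scatter), so a five-membered aromatic ring with 2 hetero atoms does not keep what pyridin-3-yl gives. Of the three groups shown here, only pyridin-3-yl reaches a number in this assay, and both five-membered aromatic rings stop at a limit of the assay: the limit of > 30000 nM in this assay, at which 2 of the 3 values shown sit. The step from compound 1 to compound 3 cannot be read, and furan-3-yl and 1H-pyrazol-1-yl therefore cannot be ranked against each other.

The compounds shown do not tell whether the six-membered ring itself or its nitrogen matters most, since a plain phenyl, a pyridin-2-yl and a pyridin-4-yl group are absent from them at this position. They also leave open whether a six-membered ring bearing an amine or a carboxylic acid, or one joined through a longer chain, would move the value away from that of compound 2, 2000 nM, in either direction.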